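Moving the Chlorine Around the Ring: Compound 4 Expected

The source may hold more compounds than are shown below. What is called first, only, known or untested is meant among the compounds shown, and "the series" means these compounds.

Of the compounds shown here, three of one core have been tested in a functional assay on HEL cells (Homo sapiens) for inhibition; on this read-out higher numbers stand for lower toxicity in this test and lower numbers for higher toxicity in this test. Compound 1 `O=C1c2ccccc2N(COCc2ccccc2)S(=O)(=O)N1Cc1ccccc1` gives > 122000 nM in this assay, a limit and not a number. Compound 2 `O=C1c2ccccc2N(Cc2ccc(Cl)c(Cl)c2)S(=O)(=O)N1Cc1ccccc1` gives > 200000 nM in this assay, again a limit. Compound 3 `O=C1c2ccccc2N(Cc2cccc(Cl)c2)S(=O)(=O)N1Cc1ccccc1` gives > 200000 nM in this assay, also a limit. Compound 3 therefore stands only at a limit, and the two other values on record are limits as well. The step that the two limits leave unreadable from compound 1 to compound 2 cannot be sized, nor can a step that the two limits leave unreadable from compound 1 to compound 3 or a step that the two limits leave unreadable from compound 2 to compound 3, because the limit of > 122000 nM in this assay, at which 1 of the 3 values shown sits, and the limit of > 200000 nM in this assay, at which 2 of the 3 values shown sit, are all the assay has reported. Compound 4 `O=C1c2ccccc2N(Cc2ccc(Cl)cc2)S(=O)(=O)N1Cc1ccccc1` differs from compound 3 by 4-chlorophenyl in place of 3-chlorophenyl on a saturated chain carbon bound to a sulfonamide nitrogen in a ring. Among the measured compounds shown here, of the measured steps, the one from compound 2 to compound 3 comes closest in kind, since it also concerns a chloro on the aromatic ring, but its size is unreadable. With nothing beyond limits to build on, the account expects no step beyond the scatter in this assay, in either direction. Compound 4 is thus expected to give 200000 nM, within 100000 nM to 400000 nM. The expected step of a number no higher from compound 3 to compound 4 (the limit leaves the size open) is, accordingly, no change worth the name.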

Compound 4, half-maximal cytotoxic concentration: > 200000 nM
Compound 4: no number, only a limit; the forecaster's own chance of this, stated with the estimate: 85%; the middle value lies on the limit itself.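

In this assay compound 4 gives > 200000 nM as a limit and not a number. Among the compounds shown here, no step to compound 4 from compound 1, compound 2 or compound 3 can be read. None of the compounds shown yields a number, which leaves open how far 3-chlorobenzyl and 4-chlorobenzyl differ in this read-out, if they differ at all.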